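The source may report more compounds than this note shows. Statements on the series, on what has been measured and on what is new or still open speak of the compounds shown alone.

Measured in a functional assay on MGC-803 cells (Homo sapiens) for inhibition, read by MTT assay, with a stated time of 72 h; on this read-out higher numbers stand for weaker inhibition and lower numbers for stronger inhibition:
compound 1 `CC(C)c1ccc(-c2nc(SCc3cn(CC(=O)NC(=O)Nc4ccccn4)nn3)nc(Nc3ccc(F)cc3)c2C#N)cc1` gives 17500 nM
compound 2 `Cc1ccc(Nc2nc(SCc3cn(CC(=O)NC(=O)Nc4ccccn4)nn3)nc(-c3ccc(C(C)C)cc3)c2C#N)cc1` gives 3360 nM
compound 3 `CC(C)c1ccc(-c2nc(SCc3cn(CC(=O)NC(=O)Nc4ccccn4)nn3)nc(Nc3ccccc3O)c2C#N)cc1` gives 16400 nM

Compound 2 gives the lowest number of the three. Both a 5.2-fold lower number from compound 1 to compound 2 (0.72 log units; beyond the scatter) and a 4.9-fold higher number from compound 2 to compound 3 (0.69 log units; beyond the scatter) lie beyond the scatter, so compound 2 stands apart from compound 1 and compound 3, which sit together (a 1.1-fold lower number from compound 1 to compound 3 (0.03 log units; within the scatter)).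

Compound 4 `Cc1ccc(Nc2nc(SCc3cn(CC(=O)NC(=O)Nc4ccccn4)nn3)nc(-c3ccc(Cl)cc3)c2C#N)cc1` differs from compound 2 in one place: chloro in place of isopropyl on an aromatic carbon. Among the measured compounds shown here, none of the measured steps touches this position; all three vary the group on the nitrogen on the aromatic ring while the 4-isopropylphenyl stays constant, so no measured step bears directly on the change. What the measured steps do show is that a single change in this series has moved the number by as much as a 5.2-fold lower number from compound 1 to compound 2 (0.72 log units; beyond the scatter) or left it unchanged, as in a 1.1-fold lower number from compound 1 to compound 3 (0.03 log units; within the scatter). For the measured compounds named here, with no precedent for this position, a change of uncertain direction is expected, near the scatter or somewhat beyond it. Compound 4 is estimated at 4500 nM (range 1500 nM to 14000 nM). This corresponds to an expected step of a 1.3-fold higher number from compound 2 to compound 4 (0.13 log units; within the scatter).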

Compound 4, half-maximal inhibitory concentration: 24000 nM
Compound 4: the middle estimate sits 5.3-fold (0.73 log units) below what was measured; measured number above the stated range.
By their numbers in this assay, from the lowest: compound 2; then compounds 3, 1 and 4 (each within the scatter of the next).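

In this assay, among the compounds shown here, the 4-isopropylphenyl group, constant through the earlier compounds, proves to be a position the number responds to: 4-chlorophenyl in its place gives a 7.1-fold higher number from compound 2 to compound 4 (0.85 log units; beyond the scatter) and so removes the advantage of the best compound so far. The series therefore responds at this position as well as at the group on the nitrogen, where the earlier change gave a 5.2-fold lower number from compound 1 to compound 2 (0.72 log units; beyond the scatter) as its counterpart. Nothing measured here explains why chloro is poorly tolerated at this position.

Only isopropyl and chloro are shown at this position, so it remains open whether a methoxy group, a tert-butyl group or an amine would give a lower or higher number. Going by these compounds, it also remains open whether the step from isopropyl to chloro keeps its size with 4-fluorophenyl or 2-hydroxyphenyl on the nitrogen.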